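This account rests on a few compounds, and the source may have more. Where it says the series, first, only, none or still open, it means among the compounds named here.

Measured in a functional assay on HUVEC cells (Homo sapiens) for inhibition, with stated times of 2 h and 72 h (on this read-out lower numbers stand for stronger inhibition and higher numbers for weaker inhibition), with limits only, no numbers:
Compound 1 `COc1cc2nccc(Oc3ccc4c(NC(=O)C5CC5)nn(C)c4c3)c2cc1OC` gives > 1000 nM
Compound 2 `COc1cc2nccc(Oc3ccc4c(NC(=O)c5cccc(C)c5)nn(C)c4c3)c2cc1OC` gives > 1000 nM
Compound 3 `COc1ccc(NC(=O)Nc2nn(C)c3cc(Oc4ccnc5cc(OC)c(OC)cc45)ccc23)cc1` gives > 1000 nM

Compound 3 has no number, only the limit of > 1000 nM in this assay, at which 3 of the 3 values shown sit, and that is a limit. The change to compound 4 `COc1cc2nccc(Oc3ccc4c(NC(=O)c5ccc(C(F)(F)F)cc5)nn(C)c4c3)c2cc1OC` is 4-(trifluoromethyl)phenyl in place of (4-methoxyphenyl)amino on a carbonyl carbon with 4-(trifluoromethyl)phenyl in place of (4-methoxyphenyl)amino on a carbonyl carbon. The closest measured change is a step that the two limits leave unreadable from compound 2 to compound 3 and the others, a step that the two limits leave unreadable from compound 1 to compound 2 and a step that the two limits leave unreadable from compound 1 to compound 3 are no more readable, so no measured size carries over. Nothing in these compounds points to a gain, so the expected change is a step that the limit leaves unreadable from compound 3 to compound 4 with no direction expected beyond the scatter. Compound 4 is estimated at 1500 nM with an expected range from 400 nM to 5000 nM and a further limit is the likeliest report.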

Compound 4, half-maximal inhibitory concentration: > 1000 nM
Compound 4 gave a limit, no number; the forecaster's own chance of this, stated with the estimate: 80%; the middle value does not contradict the limit.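

In this assay no step can be read among compound 1, compound 2, compound 3 and compound 4, since each result is a limit: the limit of > 1000 nM in this assay, at which 4 of the 4 values shown sit. The compounds shown leave open how strongly any of them inhibits, and whether the group on the carbonyl carbon matters at all.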